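Moving a halogen on the terminal phenyl ring

This account rests on a few compounds, and the source may have more. Where it says the series, first, only, none or still open, it means among the compounds named here.

Three compounds share one core and are compared in a functional assay on the whole organism (strain CD-1) with Mus musculus as the target, in the maximal electroshock model, with a stated time of 0.5 h; on this read-out higher numbers stand for an effect only at larger amounts of compound and lower numbers for an effect already at smaller amounts. Compound 1 `CC1(c2ccccc2)CC(=O)N(CC(=O)N2CCOCC2)C1=O` gives 300 mg/kg. Compound 2 `CC1(c2ccccc2)CC(=O)N(CC(=O)N2CCN(c3ccccc3)CC2)C1=O` gives 300 mg/kg, level with compound 1 and together with it the highest of the three numbers. Compound 3 `CC1(c2ccccc2)CC(=O)N(CC(=O)N2CCN(c3ccc(F)cc3)CC2)C1=O` gives 100 mg/kg, so the change a 3.0-fold lower number from compound 2 to compound 3 (0.48 log units; beyond the scatter), a modest step that lies beyond the scatter.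

Compound 4 `CC1(c2ccccc2)CC(=O)N(CC(=O)N2CCN(c3cccc(Cl)c3)CC2)C1=O` has not yet been measured in this assay. It differs from compound 2 by chloro in place of hydrogen on an aromatic carbon; seen one bond further out, phenyl becomes 3-chlorophenyl. Within the data shown here, the only measured step that bears on this is the one from compound 2 to compound 3, where a different halogen entered the same ring and the number fell by a modest amount. Compound 4 is therefore expected to show a lowering of similar size, giving an estimated step of a 2.0-fold lower number from compound 2 to compound 4 (0.30 log units; within the scatter). The expected value for compound 4 is 150 mg/kg, estimated to lie between 100 mg/kg and 300 mg/kg.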

Compound 4, minimum effective dose: 300 mg/kg
The estimate for compound 4 lay 2.0-fold (0.30 log units) below the measured number; measured number inside the range.
By their numbers in this assay, from the lowest: compound 3; then compounds 1, 2 and 4 (each within the scatter of the next).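

In this assay, chloro on the terminal phenyl ring gives no change at the digits printed from compound 2 to compound 4 (within the scatter), so a halogen on this ring does not by itself bring the number down. The listed step between the two halogenated compounds is a 3.0-fold higher number from compound 3 to compound 4 (0.48 log units; beyond the scatter), which shows that 3-chlorophenyl and 4-fluorophenyl are not interchangeable here. That step changes both the halogen and its place on the ring, so it cannot say which of the two matters, and no measured information on the cause is available.

The compounds shown leave these two changes tangled together. A 4-chlorophenyl or 3-fluorophenyl group would separate them, while a 4-methoxyphenyl group would show whether the lower number at this ring position needs a halogen at all.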